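A few compounds are considered here, and "the series" means these few. Any claim that something is new, unique, unknown or untested is made for them only; others in the source may bear on it.

Compound 1, `Cc1ccc2c(c1)oc(=O)n2C(=O)NCCCCc1ccccc1`, is one of three related carbamates tested in an assay on HEK293 cells for inhibition of acid ceramidase (Homo sapiens), with a stated time of 10 min (on this read-out lower numbers stand for stronger inhibition and higher numbers for weaker inhibition), where compound 1 gives 66 nM. Compound 2, `O=C(NCCCCc1ccccc1)n1c(=O)oc2cc(Cl)c(Cl)cc21`, carries two chlorine atoms on its fused ring system and in this assay gives 18 nM, a lower number than that of compound 1 by a margin that lies beyond the usual scatter. Compound 3, `O=C(NCCCCCCc1ccccc1)n1c(=O)oc2ccccc21`, has a longer chain between the carbamate and the terminal phenyl and in this assay gives 51 nM, which sits within the scatter of the number for compound 1; the two cannot be told apart. Among these three, compound 1 therefore has the highest number, with compound 3 close to it and compound 2 clearly lower.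

Compound 4, `O=C(NCCCCc1ccccc1)n1c(=O)oc2cc(-c3ccc(F)cc3)ccc21`, differs from compound 1 in a single place: 4-fluorophenyl in place of methyl on an aromatic carbon. Among the compounds with values here, no measured pair in this set shows exactly this kind of exchange, so the only guide is that the substituted fused ring system of compound 2 reached 18 nM. On that basis a modest step toward a lower number is expected from compound 1 to compound 4, of about a 1.9-fold lower number from compound 1 to compound 4 (0.28 log units; within the scatter), though it may not clear the scatter. Compound 4 is thus estimated to give 35 nM in this assay, within a range of 10 nM to 120 nM.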

Compound 4, half-maximal inhibitory concentration: 79 nM
Estimate against measurement, compound 4: 2.3-fold (0.35 log units) below, within the range that was stated.
By their numbers in this assay, from the lowest: compound 2; then compounds 3, 1 and 4 (each within the scatter of the next).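

In this assay, replacing methyl with 4-fluorophenyl on this aromatic carbon, which is meta to a fused ring and para to a fused ring, gives a 1.2-fold higher number from compound 1 to compound 4 (0.08 log units; within the scatter) and so leaves compound 1 and compound 4 impossible to tell apart. The earlier compounds shown here did not show this: a group of 7 heavy atoms, including a whole six-membered aromatic ring of carbon only, can take the place of a single carbon here with no measurable change in the number. This is one exchange at one position, and nothing measured here accounts for the result.

From the compounds shown here alone, whether an amine or a carboxylic acid on this same aromatic carbon would also leave the number in place stays open, as does whether a plain phenyl would match 4-fluorophenyl. Within the data shown here, also open is whether 4-fluorophenyl at this position would be accommodated as well in a compound with the longer chain of compound 3, since the only pair read so far keeps the chain of compound 1.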